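The source may hold more compounds than are shown below. What is called first, only, known or untested is meant among the compounds shown, and "the series" means these compounds.

Measured compounds in a functional assay on MCF7 cells (Homo sapiens) for cytotoxicity, read by sulforhodamine B assay, with a stated time of 48 h; on this read-out lower numbers stand for stronger inhibition of growth and higher numbers for weaker inhibition of growth:
- compound 1, `COc1cc(/C(Cl)=C/C=C(\C#N)C(=O)c2c[nH]c3ccccc23)cc(OC)c1OC`, gives 94300 nM
- compound 2, `COc1cc(/C(Cl)=C/C=C(\C#N)C(=O)c2c[nH]c3ccc(Br)cc23)cc(OC)c1OC`, gives 96500 nM
- compound 3, `COc1ccc(/C(Cl)=C/C=C(\C#N)C(=O)c2c(C)[nH]c3ccccc23)cc1OC`, gives 93000 nM

Compound 3 has the lowest of the three numbers, yet compound 1 and compound 2 lie within the scatter of it, so no order among the three is established. Among the measured compounds shown here, the single step with one change, a 1.0-fold higher number from compound 1 to compound 2 (0.01 log units; within the scatter), concerns the core of compound 1 and sits within the scatter; it is the only measured step and it does not touch the ring that is changed here.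

Compound 4, `COc1cc(/C(Cl)=C/C=C(\C#N)C(=O)c2c(C)[nH]c3ccccc23)cc(OC)c1OC`, differs from compound 3 by methoxy in place of hydrogen on an aromatic carbon. For the measured compounds named here, no measured pair in this set separates this change, so the expectation rests on compound 3 alone and on the flatness of the numbers so far. The step expected from compound 3 to compound 4 in this assay is therefore no change at the digits printed from compound 3 to compound 4 (within the scatter), none beyond the scatter. Compound 4 is estimated at 93000 nM, in the range 45000 nM to 190000 nM.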

Compound 4, concentration for total growth inhibition: 83700 nM
For compound 4 the middle estimate is 1.1-fold (0.05 log units) above the measured one; the range from low to high includes it.
By their numbers in this assay, from the lowest: compounds 4, 3, 1 and 2 (each within the scatter of the next).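

In this assay, methoxy in place of hydrogen on this aromatic carbon, ortho to a methoxy group, gives a 1.1-fold lower number from compound 3 to compound 4 (0.05 log units; within the scatter) and so stays within the scatter at this position. With that methoxy present, methyl in place of hydrogen gives a 1.1-fold lower number from compound 1 to compound 4 (0.05 log units; within the scatter) and the swap of 5-bromo-1H-indol-3-yl for 2-methyl-1H-indol-3-yl gives a 1.2-fold lower number from compound 2 to compound 4 (0.06 log units; within the scatter), so neither change separates compound 4 from its neighbours. No measurement shown offers a cause for these small steps.

All the steps shown lie within the scatter, so it remains open whether any change on this series can move the number beyond it. An amine or a carboxylic acid on this aromatic carbon, or a longer chain in place of the methyl, remains to be placed against compound 4.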